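A Small Change on the Five-Membered Ring of Compound 1

This account rests on a few compounds, and the source may have more. Where it says the series, first, only, none or still open, it means among the compounds named here.

Among the measured compounds shown here, compound 1 `O=S(=O)(c1ccc2cccnc2c1)n1cc(C2=CCNCC2)c2ccccc21` is one of two compounds measured in an assay on HEK293 cells for displacement of a labelled ligand from 5-hydroxytryptamine receptor 6 (Homo sapiens), read by scintillation counting (on this read-out lower numbers stand for stronger inhibition and higher numbers for weaker inhibition), where compound 1 gives 7 nM. This is the higher of the two numbers. Its nearest neighbour is compound 2 `COc1ccc2c(c1)c(C1=CCNCC1)cn2S(=O)(=O)c1ccc2cccnc2c1`, which in this assay gives 2 nM; the step of a 3.5-fold lower number from compound 1 to compound 2 (0.54 log units; beyond the scatter) comes from a methoxy in place of hydrogen on an aromatic carbon.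

Compound 3 `Cc1c(C2=CCNCC2)c2ccccc2n1S(=O)(=O)c1ccc2cccnc2c1` has not yet been measured. It differs from compound 1 by methyl in place of hydrogen on an aromatic carbon, placed on an aromatic carbon of a five-membered aromatic ring with one nitrogen, next to the ring nitrogen and next to the ring atom that bears a group of six heavy atoms. For the measured compounds named here, no measured step bears directly on this change: the only known step, a 3.5-fold lower number from compound 1 to compound 2 (0.54 log units; beyond the scatter), concerns a methoxy on a different ring, and it was modest. With nothing to guide the direction, compound 3 is expected to stay within the scatter of compound 1, so the expected step of a 1.1-fold higher number from compound 1 to compound 3 (0.06 log units; within the scatter) is small. Compound 3 is therefore estimated at 8 nM in this assay, within a range from 3 nM to 25 nM.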

Compound 3, inhibition constant: 18 nM
Compound 3: the middle estimate sits 2.3-fold (0.35 log units) below what was measured; measured number inside the range.
By their numbers in this assay, from the lowest: compound 2; then compound 1; then compound 3.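

In this assay, the step of a 2.6-fold higher number from compound 1 to compound 3 (0.41 log units; beyond the scatter) shows that this position, on an aromatic carbon of a five-membered aromatic ring with 1 nitrogen, next to the ring nitrogen, responds to even a small change: methyl in place of hydrogen, an entering group of 1 heavy atom, moves the number upward and beyond the scatter. The earlier step of a 3.5-fold lower number from compound 1 to compound 2 (0.54 log units; beyond the scatter) ran the other way, so the core of compound 1 now has one substitution that lowers the number and one that raises it, although these two steps differ in both the group and its place and cannot separate the two. The data shown offer no independent measurement that would account for the higher number seen with the methyl.

On these data alone, it remains open whether the rise follows from any group at this position or is particular to methyl, a question that ethyl, chlorine or methoxy in the same place could address. Also open, as far as these compounds go, is whether methyl here would raise the number by a similar step when methoxy is also present, as it is in compound 2.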